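This account rests on a few compounds, and the source may have more. Where it says the series, first, only, none or still open, it means among the compounds named here.

Of the compounds shown here, three of one shared core have been measured in a functional assay on KB cells (Homo sapiens) for antiproliferative activity, read by sulforhodamine B assay, with a stated time of 72 h; a higher number here means a weaker inhibitor of growth, a lower number a stronger inhibitor of growth. Compound 1 `CCc1cc(=O)c2ccc(OCC(C)C)c(CBr)c2o1` carries an isobutyl group on the aromatic oxygen together with an ethyl group on the pyranone ring; in this assay compound 1 reaches only the limit > 29400 nM, which is a limit rather than a number (the limit of > 29400 nM in this assay, at which 1 of the 3 values shown sits). Compound 2 `COc1ccc2c(=O)cc(C(C)Br)oc2c1CBr`, with a methyl on the aromatic oxygen and a bromoethyl group, gives 15100 nM in this assay. Compound 3 `CC(C)Oc1ccc2c(=O)cc(C(C)Br)oc2c1CBr`, in which the methyl becomes an isopropyl, gives 12800 nM in this assay. Among the two numbers shown, compound 3 has the lowest, and its nearest neighbour is compound 2, the step of a 1.2-fold lower number from compound 2 to compound 3 (0.07 log units; within the scatter) lying within the scatter.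

Compound 4 `CC(C)COc1ccc2c(=O)cc(C(C)Br)oc2c1CBr` is not yet measured. It differs from compound 3 in one place: isobutyl in place of isopropyl on an oxygen on an aromatic ring. Going by the values given here, the only measured step that bears on this change is the enlargement of the alkyl group on the aromatic oxygen from compound 2 to compound 3, which was a 1.2-fold lower number from compound 2 to compound 3 (0.07 log units; within the scatter) and within the scatter. A further enlargement by one carbon is therefore expected to move the number by no more than the scatter, so the step from compound 3 to compound 4 is estimated as a 1.0-fold higher number from compound 3 to compound 4 (0.01 log units; within the scatter). Compound 4 is accordingly expected to give about 13000 nM in this assay, within a range from 6000 nM to 30000 nM.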

Compound 4, concentration for 50% growth inhibition: 10900 nM
Beside the measured number, compound 4's estimate is 1.2-fold (0.08 log units) above it; measured number inside the range.
By their numbers in this assay, from the lowest: compounds 4, 3 and 2 (each within the scatter of the next). At a limit, above all of these: compound 1.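

In this assay, a third alkyl group on the aromatic oxygen again leaves the number within the scatter, with isobutyl taking the place of isopropyl (a 1.2-fold lower number from compound 3 to compound 4 (0.07 log units; within the scatter)). Going by these compounds alone, the methyl and isobutyl compounds also lie within the scatter of each other (a 1.4-fold lower number from compound 2 to compound 4 (0.14 log units; within the scatter)), so methyl, isopropyl and isobutyl on this oxygen cannot be told apart in this assay, and the wider span adds no trend to the single step seen before. Within the data shown here, with isobutyl held in place on the oxygen, bromo in place of hydrogen on a saturated chain carbon bound to an aromatic carbon and a saturated chain carbon gives the first single-place step beyond the scatter (an at least 2.6-fold lower number from compound 1 to compound 4 (0.43 log units; beyond the scatter)), and its size is only a bound, since compound 1 stands at a limit and not at a number: the limit of > 29400 nM in this assay, at which 1 of the 4 values shown sits.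

The compounds shown leave open whether a longer chain, a benzyl group or a chain ending in an amine on the aromatic oxygen would shift the number beyond the scatter. They also leave open whether chloro or hydroxyl in place of the bromo on that saturated chain carbon would keep the gain.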